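An anilino change on compound 1

The source may hold more compounds than are shown below. What is called first, only, known or untested is meant among the compounds shown, and "the series" means these compounds.

In a functional assay on NCI-H460 cells (Homo sapiens) for inhibition, read by MTT assay, with a stated time of 24 h, tested at 0.1 ug/mL (a lower number here means less inhibition of growth, a higher number more inhibition of growth at the concentration tested), compound 1 (`CC(=O)SCCC(CCCCC(=O)O)SC(C)=O`) gives 9.96% at the one concentration tested. Compound 2 (`O=C(CCCCC1CCSS1)NO`) gives 3.9% in this assay and lies within the scatter of compound 1, so the two cannot be ranked. Compound 3 (`O=C(CCCCC1CCSS1)Nc1cccc(C(F)(F)F)c1`) is recorded as "not active" (no number reported) in this assay and offers no number for comparison. Compound 1 therefore stands level with compound 2, and both figures are small on this scale of growth inhibition.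

Compound 4 (`CC(=O)SCCC(CCCCC(=O)Nc1ccccc1)SC(C)=O`) keeps the core of compound 1 and differs in one place, with anilino in place of hydroxy on a carbonyl carbon. This brings in a six-membered aromatic ring of carbon only. For the measured compounds named here, no pair of measured compounds isolates this change, so any expectation rests on indirect evidence. Compound 3 also holds an aromatic ring of carbon only, and its record of "not active" (no number reported) in this assay gives no sign of a gain. The expected a number 2 percentage points lower from compound 1 to compound 4 (within the scatter) is therefore no change beyond the scatter, in either direction. Compound 4 is estimated at 8% in this assay, with an expected range from 0% to 22% around that figure.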

Compound 4, percent growth inhibition at one concentration: 15.4%
The estimate for compound 4 lay 7.4 percentage points below the measured number; measured number inside the range.
By their numbers in this assay, from the lowest: compounds 2, 1 and 4 (each within the scatter of the next, the first and the last beyond it).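

In this assay, for the compounds shown here, the step of a number 5.4 percentage points higher from compound 1 to compound 4 (within the scatter) is the first measured one at this carbonyl carbon, and it lies within the scatter. The position therefore takes anilino, with seven heavy atoms and a six-membered aromatic ring of carbon only, in place of the single heavy atom of hydroxy, with no change that can be told from repeated-measurement noise, and the number stays small on this scale of growth inhibition. No measured evidence bears on the reasons for this outcome.

The compounds shown leave open whether a different group on this carbonyl carbon, such as benzylamino, a methoxy ester or an anilino ring carrying trifluoromethyl, would move the number beyond the scatter on the core of compound 1. They also leave open how compound 1 and compound 4 would compare across a range of concentrations, since each is described here by a single reading at one concentration.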